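The source may report more compounds than this note shows. Statements on the series, on what has been measured and on what is new or still open speak of the compounds shown alone.

Measured so far in a functional assay on HepG2 cells (Homo sapiens) for cytotoxicity, read by crystal violet staining, with a stated time of 72 h; on this read-out lower numbers stand for stronger inhibition and higher numbers for weaker inhibition:

compound 1, `COc1cc(/C=C/C(=O)/C=C(O)/C=C/c2ccc(O[C@H]3C=C(C)[C@@H](O)C[C@@H]3[C@@H](C)CCC=C(C)C)c(OC)c2)ccc1O`: 25000 nM
compound 2, `COc1cc(/C=C/C(=O)/C=C(O)/C=C/c2ccc(O[C@H]3C[C@H]([C@@H](C)CCC=C(C)C)[C@@H](O)C=C3C)c(OC)c2)ccc1O`: 64100 nM
compound 3, `COc1cc(/C=C/C(=O)/C=C(O)/C=C/c2ccc(O[C@H]3C[C@H]([C@@H](C)CCC=C(C)C)C=C[C@@]3(C)O)c(OC)c2)ccc1O`: 29500 nM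

Compound 3 stands second highest of the three numbers. Its nearest neighbour is compound 1, whose number is lower by a gap that lies within the scatter, so the two are not told apart here. The furthest is compound 2, whose number is higher by a gap that lies beyond the scatter. For the measured compounds named here, all three share the same core and differ only in the terpenoid ether portion, and no pair among them differs in one place alone, so no single-change step size is known.

Compound 4, `COc1cc(/C=C/C(=O)/C=C(O)/C=C/c2ccc(O[C@H]3C[C@H]([C@@H](C)CC(=O)C=C(C)C)C=C[C@@]3(C)O)c(OC)c2)ccc1O`, has not yet been measured. It differs from compound 3 in one place: (2-methylprop-1-en-1-yl)carbonyl in place of 3-methylbut-2-en-1-yl on a saturated chain carbon, two bonds along the chain from a saturated ring carbon. Going by the values given here, no measured pair shows the effect of this kind of change in this assay, so the step can only be expected by analogy with the narrow spread of the series so far. The expected step in this assay is small, direction uncertain, most likely none beyond the scatter, perhaps a slight lowering. The value for compound 4 is expected at 25000 nM, with a range from 8000 nM to 80000 nM. The step of a 1.2-fold lower number from compound 3 to compound 4 (0.07 log units; within the scatter) is expected to stay within the scatter.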

Compound 4, half-maximal inhibitory concentration: 18300 nM
The estimate for compound 4 lay 1.4-fold (0.14 log units) above the measured number; the range from low to high includes it.
By their numbers in this assay, from the lowest: compounds 4, 1 and 3 (each within the scatter of the next); then compound 2.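

In this assay, the series now has its first single-place step, a 1.6-fold lower number from compound 3 to compound 4 (0.21 log units; within the scatter), and this step does not separate the two compounds. The chain position, on a saturated chain carbon, two bonds along the chain from a saturated ring carbon, therefore accepts (2-methylprop-1-en-1-yl)carbonyl in place of 3-methylbut-2-en-1-yl with no change that can be told from the scatter, even though the entering group brings a carbonyl oxygen and a further double bond outside the aromatic rings. No separate data on the compounds bear on this result.

Still open, from the compounds shown here alone, is whether any replacement at this chain position can move the number beyond the scatter, for example a hydroxyl on the same chain carbon, an amine, a carboxylic acid or a longer chain. For the compounds shown here, also open is whether the same change to (2-methylprop-1-en-1-yl)carbonyl gives a similar step on the differently substituted terpenoid ether portions of compound 1 and compound 2, since the single step read here comes from the portion shared by compound 3 and compound 4.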